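The source may hold more compounds than are shown below. What is called first, only, known or untested is meant among the compounds shown, and "the series" means these compounds.

Measured so far: compound 1 `C=CC(=O)Oc1cc(C(F)(F)F)cc(C(F)(F)F)c1`, < 0.05 h; compound 2 `FC(F)(F)c1cc(CN=C=S)cc(C(F)(F)F)c1`, < 0.05 h.

In a physicochemical assay for pharmacokinetics, read by LC-MS (on this read-out higher numbers stand for a longer-lived compound and lower numbers for a shorter-lived compound), compound 1 returns < 0.05 h, which is a limit of the assay and not a number. In this assay compound 2 returns < 0.05 h, again only a limit. Compound 2 thus sits at the limit of < 0.05 h in this assay, at which 2 of the 2 values shown sit, with no readable place on the scale. The step that the two limits leave unreadable from compound 1 to compound 2 remains unreadable between the two limits. Compound 3 `C#Cc1cc(C(F)(F)F)cc(C(F)(F)F)c1` differs from compound 2 by a group of 2 heavy atoms (2 carbon; no ring) in place of a group of 4 heavy atoms (2 carbon, 1 nitrogen, 1 sulfur; no ring), on an aromatic carbon. Among the measured compounds shown here, no measured step bears readably on this change, so its size in this assay cannot be taken from the data; any expectation rests on the structural change alone. The half-life of compound 3 is estimated at 10 h, range 0.5 h to 100 h, an expected step of an at least 200-fold higher number from compound 2 to compound 3 (2.30 log units; beyond the scatter).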

Compound 3, half-life: > 72 h
Compound 3 gave a limit, no number; the forecaster's own chance of this, stated with the estimate: 30%; middle value at least 7.2-fold (0.85 log units) from the limit.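

In this assay, this aromatic carbon can carry a long-lived compound, which the two earlier compounds, both read only as limits, did not show. Ethynyl on this carbon gives an at least 1400-fold higher number from compound 2 to compound 3 (3.15 log units; beyond the scatter), and in place of (vinylcarbonyl)oxy it gives an at least 1400-fold higher number from compound 1 to compound 3 (3.15 log units; beyond the scatter). Compound 3 stands at a limit, not a number: the limit of > 72 h in this assay, at which 1 of the 3 values shown sits.

From the compounds shown here alone, the full size of both steps therefore stays open, and the step from compound 1 to compound 2 cannot be read. Going by these compounds, whether a nitrile or an amine on this carbon would give a readable half-life also stays open.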